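A few compounds are considered here, and "the series" means these few. Any claim that something is new, unique, unknown or untested is made for them only; others in the source may bear on it.

Measured so far in a functional assay on PC-3 cells (Homo sapiens) for inhibition, read by sulforhodamine B assay, with a stated time of 48 h; on this read-out higher numbers stand for weaker inhibition and lower numbers for stronger inhibition:
Compound 1 `O=c1c(C(=S)Nc2ccccc2)coc2cc(Cl)ccc12` gives 90800 nM.
Compound 2 `O=c1c(C2N=C(c3ccccc3)SS2)coc2ccc(Cl)cc12` gives 52700 nM.
Compound 3 `O=c1c(C2N=C(c3ccccc3)SS2)coc2ccc(F)cc12` gives > 100000 nM, which is a limit of the assay and not a number.

Compound 3 therefore sits at the point where the assay stops reporting numbers, described by the limit of > 100000 nM in this assay, at which 1 of the 3 values shown sits. Compound 4 `O=c1c(C2N=C(c3ccccc3)SS2)coc2ccccc12` differs from compound 3 by hydrogen in place of fluoro on an aromatic carbon. Going by the values given here, the only measured step that bears on this change is the halogen swap, an at least 1.8-fold higher number from compound 2 to compound 3 (0.27 log units; that floor lies within the scatter), which pointed toward weaker inhibition but whose floor lies within the scatter. Among the compounds with values here, no measured pair shows complete removal of the halogen, so the expectation rests on that single step. For compound 4 the step that the limit leaves unreadable from compound 3 to compound 4 is expected to be small, with inhibition staying very weak and a fair chance of another limit. Compound 4 is thus estimated at 110000 nM, within 40000 nM to 300000 nM.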

Compound 4, half-maximal inhibitory concentration: > 100000 nM
Compound 4: a limit, no number (the forecaster's own chance of this, stated with the estimate: 55%); the middle value does not contradict the limit.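

Hydrogen in place of chloro gives an at least 1.8-fold higher number from compound 2 to compound 4 (0.27 log units; that floor lies within the scatter), so with the halogen gone entirely, compound 4 shows the same floor as the swap to fluoro, and neither floor clears the scatter. Among these compounds, only chloro at this position gives a number. The step between fluoro and hydrogen cannot be read because compound 3 and compound 4 both sit at one limit: the limit of > 100000 nM in this assay, at which 2 of the 4 values shown sit.

From the compounds shown here alone, whether an amine or a methoxy group at this position would give a number remains open. So does the true size of any loss on leaving chloro.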